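Amide to urea on a methoxy-bearing pyrazole series

The compounds below may be only part of what the source reports. "The series", "measured", "known", "first", "only" and "open" are said of these compounds alone.

The study tracks growth inhibition in a functional assay on NCI-H23 cells (Homo sapiens) for inhibition, read by sulforhodamine B assay, with a stated time of 48 h (on this read-out lower numbers stand for stronger inhibition of growth and higher numbers for weaker inhibition of growth), for a small set of closely related pyrazoles. Compound 1, `O=C(Nc1cccc(-n2cc(-c3ccncc3)c(-c3ccc(Cl)c(O)c3)n2)c1)Nc1cccc(C(F)(F)F)c1`, carries a urea linker and a hydroxyl-bearing aryl group; in this assay compound 1 reaches only a limit, > 32500 nM. Compound 2, `COc1cc(-c2nn(-c3cccc(NC(=O)c4cccc(C(F)(F)F)c4)c3)cc2-c2ccncc2)ccc1Cl`, replaces that hydroxyl with a methoxy group and links the outer trifluoromethylphenyl ring through an amide; in this assay compound 2 gives 32500 nM. Among the numbers shown, compound 2 is the only compound with a measured value, and that value sits at the same point as the limit, as noted in the limit of > 32500 nM in this assay, at which 1 of the 2 values shown sits.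

Compound 3, `COc1cc(-c2nn(-c3cccc(NC(=O)Nc4cccc(C(F)(F)F)c4)c3)cc2-c2ccncc2)ccc1Cl`, differs from compound 2 in one place: (3-(trifluoromethyl)phenyl)amino in place of 3-(trifluoromethyl)phenyl on a carbonyl carbon. Going by the values given here, no measured step of this kind is available within the set.

Compound 3 is expected to fall close to compound 2, with a step from no change at the digits printed from compound 2 to compound 3 (within the scatter) that is not expected to go beyond the scatter. The estimate for compound 3 in this assay is 32500 nM, with a range from 15000 nM to 40000 nM, and it is likely that only a limit is reported.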

Compound 3, concentration for total growth inhibition: 3410 nM
Estimate against measurement, compound 3: 9.5-fold (0.98 log units) above; the whole stated range lies above it.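

In this assay, going by these compounds alone, putting (3-(trifluoromethyl)phenyl)amino in place of 3-(trifluoromethyl)phenyl on a carbonyl carbon gives a 9.5-fold lower number from compound 2 to compound 3 (0.98 log units; beyond the scatter), so this place on the linker, which the earlier compounds left untested by any measured step, does respond to the change from amide to urea. Compound 1 is held at a limit, > 32500 nM, and that entry is a limit and not a number. With the urea kept, methyl in place of hydrogen on an oxygen on an aromatic ring gives an at least 9.5-fold lower number from compound 1 to compound 3 (0.97 log units; beyond the scatter), which shows that the urea alone does not carry the result, although the true size of this step stays unknown and can be read only as a bound: the limit of > 32500 nM in this assay, at which 1 of the 3 values shown sits.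

The compounds shown leave open whether the gain comes from the entering nitrogen itself or from its hydrogen, a question that an N-methyl urea or a carbamate oxygen at the same place could settle. They also leave open how far the oxygen substituent can be changed with the urea in place, for example with an ethoxy group or a longer chain in place of the methoxy group.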